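Benzyloxy on the pendant phenyl of a bis-chalcone

A few compounds are considered here, and "the series" means these few. Any claim that something is new, unique, unknown or untested is made for them only; others in the source may bear on it.

Three compounds of this bis-chalcone series carry a result in a functional assay on MCF7 cells (Homo sapiens) for cytotoxicity, read by MTT assay, with a stated time of 24 h; on this read-out lower numbers stand for stronger inhibition and higher numbers for weaker inhibition. Compound 1 `Cc1cc(O)c(C(=O)/C=C/c2ccccc2Cl)c(-c2ccccc2)c1C(=O)/C=C/c1ccccc1Cl` is recorded as "not active" (no number reported). Compound 2 `COc1ccc(/C=C/C(=O)c2c(C)cc(O)c(C(=O)/C=C/c3ccc(OC)c(OC)c3)c2-c2ccccc2)cc1OC` is likewise recorded as "not active" (no number reported) in this assay. Among the measured compounds shown here, compound 3 `Cc1cc(O)c(C(=O)/C=C/c2ccc(OCc3ccccc3)cc2)c(-c2ccc(Br)cc2)c1C(=O)/C=C/c1ccc(OCc2ccccc2)cc1` is the only member with a number, giving 20000 nM in this assay. For the measured compounds named here, compound 2 therefore stands without a single number, alongside one further entry of the same kind, and no single-point step between measured compounds exists in the set.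

Compound 4 `COc1ccc(/C=C/C(=O)c2c(C)cc(O)c(C(=O)/C=C/c3ccc(OC)c(OC)c3)c2-c2ccc(OCc3ccccc3)cc2)cc1OC` differs from compound 2 by benzyloxy in place of hydrogen on an aromatic carbon. Going by the values given here, no measured pair isolates this change, so the size of the step in this assay cannot be read from the data; the nearest reference is compound 3, which carries benzyloxy groups elsewhere and reaches only a weak number. For compound 4 a weak result in this assay is therefore expected, with an estimated value of 25000 nM and a range from 8000 nM to 80000 nM, and a substantial chance that again no number is reported.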

Compound 4, half-maximal inhibitory concentration: 30000 nM
For compound 4 the middle estimate is 1.2-fold (0.08 log units) below the measured one, within the range that was stated.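

In this assay, among the compounds shown here, compound 2 carries no single number, so no step to compound 4 can be read. The size of the change on adding benzyloxy to the pendant phenyl stays open, and no available evidence bears on a cause.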